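Swapping Trifluoromethyl for Methoxyphenyl: What to Expect

This account rests on a few compounds, and the source may have more. Where it says the series, first, only, none or still open, it means among the compounds named here.

Compound 1 `CC(Oc1ccc(CCC(=O)O)cc1)c1ccccc1` gives 106% in a functional assay on 1321-N1 cells for agonist activity at Free fatty acid receptor 1 (Homo sapiens), read by calcium flux; on this read-out higher numbers stand for larger maximal responses and lower numbers for smaller maximal responses.
Compound 2 `O=C(O)CCc1ccc(NCc2cccc(Br)c2)cc1` gives 110% in this assay.
Compound 3 `O=C(O)CCc1ccc(NCc2cccc(C(F)(F)F)c2)cc1` gives 102% in this assay.

Compound 3 has the lowest of the three numbers, but its gaps to compound 1 and to compound 2 both lie within the scatter, so the three are effectively level. Compound 4 `COc1ccccc1-c1cccc(CNc2ccc(CCC(=O)O)cc2)c1` differs from compound 3 in one place: 2-methoxyphenyl in place of trifluoromethyl on an aromatic carbon. For the measured compounds named here, only one measured step touches that same position, a number 8 percentage points lower from compound 2 to compound 3 (within the scatter), and it stayed within the scatter. With just that one step as a guide, no shift beyond the scatter is expected in this assay from compound 3 to compound 4, so the expected step is a number 2 percentage points higher from compound 3 to compound 4 (within the scatter). Compound 4 is therefore estimated at 104%, within a range from 88% to 120%.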

Compound 4, largest response reached (reported as efficacy), in percent of the reference or control that the assay uses: 109%
Beside the measured number, compound 4's estimate is 5 percentage points below it, and the stated range covers the measured number.
By their numbers in this assay, from the lowest: compounds 3, 1, 4 and 2 (each within the scatter of the next).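

Trifluoromethyl has 4 heavy atoms and no ring, while 2-methoxyphenyl has 8 heavy atoms and a six-membered aromatic ring of carbon only. Even so, this assay shows a number 7 percentage points higher from compound 3 to compound 4 (within the scatter) for this swap and a number 1 percentage points lower from compound 2 to compound 4 (within the scatter) when the same group replaces bromo. This position on the aromatic ring therefore takes a group with a whole extra ring without any shift in maximal response beyond the scatter.

From the compounds shown here alone, whether an amine or a carboxylic acid at this position would also leave the response level remains open. Nothing available explains why the response stays level across these groups.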